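The source may hold more compounds than are shown below. What is called first, only, known or untested is meant among the compounds shown, and "the series" means these compounds.

Compound 1 `COc1ccc(CSc2nnc([C@@H](C)c3ccc4cc(OC)ccc4c3)n2-c2ccc(Cl)cc2)cc1`: <= 400000 nM (a limit, not a number)
Compound 2 `COc1cccc(CSc2nnc([C@@H](C)c3ccc4cc(OC)ccc4c3)n2-c2ccc(Cl)cc2)c1`: 138000 nM
Compound 3 `COc1ccc2cc([C@H](C)c3nnc(SCc4ccc(Cl)cc4)n3-c3ccc(Cl)cc3)ccc2c1`: 5800 nM

In a functional assay on PC-3 cells (Homo sapiens) for cytotoxicity, read by MTT assay (on this read-out higher numbers stand for weaker inhibition and lower numbers for stronger inhibition), compound 3 gives 5800 nM, the lower of the two true numbers. Compound 4 `COc1ccc2cc([C@H](C)c3nnc(SCc4ccc(F)cc4)n3-c3ccc(Cl)cc3)ccc2c1` changes one atom of compound 3: fluoro in place of chloro on an aromatic carbon. The fluoro sits para to a large group. Steps involving compound 1 cannot be sized, leaving one readable step at this end of the molecule: a 24-fold lower number from compound 2 to compound 3 (1.38 log units; beyond the scatter). Within the data shown here, that step changed both the group and its place, and no measured pair compares chloro with fluoro. A much smaller step is therefore expected in this assay, probably towards a modestly higher number. The estimated step is a 1.7-fold higher number from compound 3 to compound 4 (0.24 log units; within the scatter). For compound 4, the expected value is 10000 nM, within an estimated range of 3000 nM to 40000 nM.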

Compound 4, half-maximal inhibitory concentration: 10800 nM
Compound 4: middle estimate off by 1.1-fold (0.03 log units), on the low side; the measured number falls inside the stated range.
By their numbers in this assay, from the lowest: compounds 3 and 4 (each within the scatter of the next); then compound 2.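

In this assay, among these compounds, the first direct comparison of two halogens on this aromatic carbon reads a 1.9-fold higher number from compound 3 to compound 4 (0.27 log units; within the scatter), so chloro and fluoro cannot be told apart here. The large step seen earlier with 4-chlorobenzyl also appears with 4-fluorobenzyl: a 13-fold lower number from compound 2 to compound 4 (1.11 log units; beyond the scatter). Compound 1 has only a limit, so steps from it cannot be read: the limit of <= 400000 nM in this assay, at which 1 of the 4 values shown sits.

Still open, from the compounds shown here alone, is how an amine or a carboxylic acid on this aromatic carbon would read. Also open, going by these compounds, is whether a chloro or fluoro group would keep these values on a different ring carbon.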